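This account rests on a few compounds, and the source may have more. Where it says the series, first, only, none or still open, it means among the compounds named here.

Compound 1 `O=S(=O)(NCCNCc1cccc2ccccc12)c1cc(C(F)(F)F)cc(C(F)(F)F)c1`: 24000 nM
Compound 2 `O=S(=O)(NCCCNCc1ccc(Cl)c(C(F)(F)F)c1)c1cc(C(F)(F)F)cc(C(F)(F)F)c1`: 10000 nM
Compound 3 `O=S(=O)(NCCCNCC1COc2ccccc2O1)c1cc(C(F)(F)F)cc(C(F)(F)F)c1`: 3400 nM

In a functional assay on PANC-1 cells (Homo sapiens) for inhibition, read by MTT assay, with a stated time of 72 h (on this read-out lower numbers stand for stronger inhibition of growth and higher numbers for weaker inhibition of growth), compound 2 gives 10000 nM, the second highest of the three numbers, with compound 1 standing higher and compound 3 standing lower. Compound 4 `O=S(=O)(NCCCNCc1cccc(Cl)c1)c1cc(C(F)(F)F)cc(C(F)(F)F)c1` differs from compound 2 in one place: 3-chlorophenyl in place of 4-chloro-3-(trifluoromethyl)phenyl on a saturated chain carbon bound to an amine nitrogen. Going by the values given here, the only measured step at that same place is a 2.9-fold lower number from compound 2 to compound 3 (0.47 log units; beyond the scatter), where a wholly different ring system entered. Among the compounds with values here, no measured step removes a trifluoromethyl from the aryl group while keeping a chlorophenyl. The step to compound 3 shows the attached ring can shift the number modestly, but gives no direction for this smaller change, so no step beyond the scatter is expected, a 1.2-fold higher number from compound 2 to compound 4 (0.08 log units; within the scatter). Compound 4 is therefore estimated at 12000 nM, within a range from 5000 nM to 30000 nM.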

Compound 4, concentration for 50% growth inhibition: 12000 nM
Compound 4: the middle estimate sits on the measured number at the digits printed; the range from low to high includes it.
By their numbers in this assay, from the lowest: compound 3; then compounds 2, 4 and 1 (each within the scatter of the next, the first and the last beyond it).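

In this assay, taking the trifluoromethyl off the aryl group while keeping the chlorine leaves the number within the scatter, with a 1.2-fold higher number from compound 2 to compound 4 (0.08 log units; within the scatter) on this saturated chain carbon. The 2,3-dihydro-1,4-benzodioxin-2-yl group also stands clear of this simpler 3-chlorophenyl group, with a 3.5-fold higher number from compound 3 to compound 4 (0.55 log units; beyond the scatter) in the same position. Nothing measured here accounts for either step.

The compounds shown leave open whether an unsubstituted phenyl or a nitrile in place of the chlorine would give a similar number. They also leave open whether a longer chain would preserve the lower number of compound 3.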